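The source may hold more compounds than are shown below. What is called first, only, known or untested is meant among the compounds shown, and "the series" means these compounds.

In a functional assay on HCT-116 cells (Homo sapiens) for antiproliferative activity, read by MTT assay, with a stated time of 48 h (a lower number here means a stronger inhibitor, a higher number a weaker inhibitor), compound 1 (`COc1ccc(CN(C(=O)CSc2nc3ccccc3s2)c2cc(OC)c(OC)c(OC)c2)cc1`) gives 426 nM and compound 3 (`COc1ccc(CN(C(=O)CSc2nc3cc(Cl)ccc3s2)c2cc(OC)c(OC)c(OC)c2)cc1O`) gives 429 nM. Compound 2 (`COc1cc(CN(C(=O)CSc2nc3ccccc3s2)c2cc(OC)c(OC)c(OC)c2)cc(OC)c1OC`) gives 65300 nM, the highest number of the three. Compound 4 (`COc1cc(N(Cc2ccc(F)cc2)C(=O)CSc2nc3ccccc3s2)cc(OC)c1OC`) has not yet been measured, and it differs from compound 2 as follows: 4-fluorophenyl in place of 3,4,5-trimethoxyphenyl on a saturated chain carbon bound to an amide-type nitrogen. Among the measured compounds shown here, one measured step bears on this change at the same place, a 150-fold higher number from compound 1 to compound 2 (2.19 log units; beyond the scatter), when 3,4,5-trimethoxyphenyl replaced 4-methoxyphenyl. For the measured compounds named here, that step was large, so removing 3,4,5-trimethoxyphenyl should undo much of it, although no measured compound yet carries 4-fluorophenyl. The expected change in this assay is therefore a large fall, a 65-fold lower number from compound 2 to compound 4 (1.81 log units; beyond the scatter). Compound 4 is estimated at 1000 nM, with an expected range from 200 nM to 6000 nM.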

Compound 4, half-maximal inhibitory concentration: 59800 nM
The estimate for compound 4 lay 60-fold (1.78 log units) below the measured number; measured number outside the range, above it.
By their numbers in this assay, from the lowest: compounds 1 and 3 (each within the scatter of the next); then compounds 4 and 2 (each within the scatter of the next).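

In this assay, 4-fluorophenyl in place of 3,4,5-trimethoxyphenyl brings no real change (a 1.1-fold lower number from compound 2 to compound 4 (0.04 log units; within the scatter)), so removing the trimethoxyphenyl does not by itself recover the low number. Fluoro in place of methoxy on the aromatic ring gives a large step (a 140-fold higher number from compound 1 to compound 4 (2.15 log units; beyond the scatter)), which shows that a single para-free swap of this one group matters greatly. Among compounds 1, 2 and 4, only the 4-methoxyphenyl of compound 1 gives a low number.

From the compounds shown here alone, whether a 4-ethoxyphenyl or 4-chlorophenyl group would behave like 4-methoxyphenyl or like 4-fluorophenyl remains open. No measurement at hand explains why these groups differ.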